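Amino for Hydrogen on a Benzyl-Substituted Chloropurine Scaffold

The compounds below may be only part of what the source reports. "The series", "measured", "known", "first", "only" and "open" are said of these compounds alone.

Compound 1 `ClCc1ccc(Cn2cnc3c(Cl)ncnc32)cc1` and compound 2 `Nc1nc(Cl)c2ncn(Cc3ccc(CCl)cc3)c2n1` share a core and differ by one change: amino in place of hydrogen on an aromatic carbon. In a functional assay on SNB-19 cells (Homo sapiens) for cytotoxicity, read by sulforhodamine B assay, with a stated time of 48 h (on this read-out higher numbers stand for weaker inhibition of growth and lower numbers for stronger inhibition of growth), compound 1 gives 21900 nM, and compound 2 gives 20000 nM; the step of a 1.1-fold lower number from compound 1 to compound 2 (0.04 log units; within the scatter) is within the scatter. Compound 3 `ClCc1ccccc1Cn1cnc2c(Cl)ncnc21` has the same atoms as compound 1 joined differently; the difference between the two cores is not broken down here. For compound 3 this assay reports only a limit, > 100000 nM, and the limit of > 100000 nM in this assay, at which 1 of the 3 values shown sits, records where that limit sits. Compound 4 `Nc1nc(Cl)c2ncn(Cc3ccccc3CCl)c2n1` is to be measured in this assay and differs from compound 3 by amino in place of hydrogen on an aromatic carbon, the same change as from compound 1 to compound 2. Since that change made no step beyond the scatter, compound 4 is expected to stay near the limit of compound 3, with a step that the limit leaves unreadable from compound 3 to compound 4 as the expected step. Compound 4 is therefore estimated at 120000 nM, between 50000 nM and 300000 nM.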

Compound 4, concentration for total growth inhibition: 27500 nM
Estimate against measurement, compound 4: 4.4-fold (0.64 log units) above, outside the stated range (below it).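

In this assay, amino in place of hydrogen on an aromatic carbon gives an at least 3.6-fold lower number from compound 3 to compound 4 (0.56 log units; beyond the scatter), whereas the same change gave a 1.1-fold lower number from compound 1 to compound 2 (0.04 log units; within the scatter). This shows that the change does not carry over from one core to the other with the same size: the same change on two cores in this assay, a 1.1-fold lower number (0.04 log units; within the scatter) from compound 1 to compound 2 and an at least 3.6-fold lower number (0.56 log units; beyond the scatter) from compound 3 to compound 4, at least 3.3-fold (0.52 log units) apart, beyond the scatter of two such steps It does not show how large the second step truly is or why the two cores part, as compound 3 is known only through a limit: the limit of > 100000 nM in this assay, at which 1 of the 4 values shown sits.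

The compounds shown leave open whether a methylamino or a hydroxyl group on that aromatic carbon would follow amino on either core. As far as these compounds go, whether any other core would behave like that of compound 1 or that of compound 3 also stays open.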